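Biphenyl ethers: hydroxy added to compound 2

A few compounds are considered here, and "the series" means these few. Any claim that something is new, unique, unknown or untested is made for them only; others in the source may bear on it.

Measured so far:
compound 1, `COc1ccccc1-c1ccccc1O`: 54 ug/mL
compound 2, `COc1ccc(-c2ccccc2)c(OC)c1`: 27 ug/mL

Both numbers come from an ADME assay on HEK293 cells (Homo sapiens) for cytotoxicity, read by MTT assay, with a stated time of 3 days; a higher number here means a weaker inhibitor, a lower number a stronger inhibitor. Compound 2 stands at 27 ug/mL; its nearest neighbour is compound 1, whose 54 ug/mL lies within the usual scatter of that number, so the pair shows no difference that can be read as real.

Compound 3, `COc1ccc(-c2ccccc2O)c(OC)c1`, is not yet measured in this assay. Against compound 2 the change is hydroxy in place of hydrogen on an aromatic carbon, a hydroxy in place of hydrogen on an aromatic carbon of a six-membered aromatic ring of carbon only, ortho to a large group. Among the compounds with values here, no step between measured compounds covers this change. Compound 1 carries a hydroxy on the same kind of ring and its number sits within the scatter of compound 2, so no step beyond the scatter is expected in either direction. Compound 3 is estimated at 30 ug/mL, with a range of 12 ug/mL to 75 ug/mL. The expected step from compound 2 is a 1.1-fold higher number from compound 2 to compound 3 (0.05 log units; within the scatter).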

Compound 3, half-maximal inhibitory concentration: > 100 ug/mL
Compound 3: only a limit was reported; the forecaster's own chance of this, stated with the estimate: 5%; middle value at least 3.3-fold (0.52 log units) from the limit.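

In this assay compound 3 has no number, only a limit of the assay: the limit of > 100 ug/mL in this assay, at which 1 of the 3 values shown sits. Within the data shown here, on an aromatic carbon, ortho to a large group, hydroxy in place of hydrogen gives an at least 3.7-fold higher number from compound 2 to compound 3 (0.56 log units; beyond the scatter), so this single change on the core of compound 2 moves the read-out by more than the scatter, something no earlier pair could show. A further change in one place gives an at least 1.8-fold higher number from compound 1 to compound 3 (0.26 log units; that floor lies within the scatter), so this second change has only a floor and cannot be called a real shift on these data.

From the compounds shown here alone, the true size of both steps stays open, as both rest on a limit. Also open, going by these compounds, is whether an amine or a carboxylic acid on the same aromatic carbon would give a step like that of hydroxy.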